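The source may hold more compounds than are shown below. What is called first, only, known or untested is meant among the compounds shown, and "the series" means these compounds.

Series around the shared core of compound 1 `O=C(O)CCc1cccc2c1B(O)OC2`. In a functional assay on HCT-116 cells (Homo sapiens) for antiproliferative activity, read by MTT assay, with a stated time of 72 h (a lower number here means a stronger inhibitor, a higher number a weaker inhibitor), compound 1 reaches only a limit, > 100000 nM. Compound 2 `O=C(CCc1cccc2c1B(O)OC2)NCc1ccccc1` carries a benzyl group on the amide-type nitrogen. In this assay compound 2 likewise reaches only a limit, > 100000 nM. Among the measured compounds shown here, compound 3 `O=C(CCc1cccc2c1B(O)OC2)Nc1ccc(Br)cc1` carries 4-bromophenyl on that nitrogen, and in this assay compound 3 gives 46000 nM, the only number measured so far. For compound 1 and compound 2 only limits are in hand. For the measured compounds named here, the one measured step, an at least 2.1-fold lower number from compound 2 to compound 3 (0.33 log units; beyond the scatter), is read against (the limit of > 100000 nM in this assay, at which 2 of the 3 values shown sit), so its true size is open.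

Compound 4 `O=C(CCc1cccc2c1B(O)OC2)Nc1ccc([N+](=O)[O-])cc1` differs from compound 3 in one place: nitro in place of bromo on an aromatic carbon. Going by the values given here, no measured step swaps one group on that aromatic ring for another; the single measured step exchanged the whole group on the amide-type nitrogen, so it bears on this change only loosely and gives no direction. With one numeric value in hand, no step beyond the scatter is expected in this assay in either direction. The estimate for compound 4 is 45000 nM, between 15000 nM and 100000 nM, which means an expected step of a 1.0-fold lower number from compound 3 to compound 4 (0.01 log units; within the scatter) that stays within the scatter, with a fair chance that compound 4 returns only a limit.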

Compound 4, half-maximal inhibitory concentration: > 100000 nM
Compound 4 gave a limit, no number; the forecaster's own chance of this, stated with the estimate: 35%; at least 2.2-fold (0.34 log units) between middle value and limit.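

With the aromatic ring on the amide-type nitrogen kept and only the group on the aromatic carbon para to a large group exchanged, this assay shows an at least 2.1-fold higher number from compound 3 to compound 4 (0.33 log units; beyond the scatter). An aromatic ring directly on that nitrogen is therefore not enough by itself to give a measurable value in this series, and the group at this place matters; compound 4 reaches only a limit, > 100000 nM. On these data alone, the true size of the step stays open, since its higher end is a limit and not a number: the limit of > 100000 nM in this assay, at which 3 of the 4 values shown sit.

The compounds shown hold only bromo and nitro at this place, so they cannot tell whether bromo is specifically needed or whether chloro, methoxy or an amine there would also give a measurable value. Nor can they tell how a longer chain between the amide-type carbonyl and the shared core would read against compound 3, whose value remains the only number in the series and so gives no second measured point for a trend.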